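The source may report more compounds than this note shows. Statements on the series, on what has been measured and on what is new or still open speak of the compounds shown alone.

Of the compounds shown here, two with a shared core have been measured in an ADME assay on the whole organism (Mus musculus, strain Balb/c) for pharmacokinetics, at a dose of 10 mg/kg by the oral route; on this read-out higher numbers stand for higher exposure at the dose given and lower numbers for lower exposure. Compound 1, `C[C@@H]1CN(c2sc(C(F)(F)F)nc2-c2nc3ccccc3[nH]2)CCN1C(=O)Cn1cccn1`, gives 720 ng.h/mL in this assay. Compound 2, `Cc1nc(C)n(CC(=O)N2CCN(c3sc(C(F)(F)F)nc3-c3nc4ccc(C5CCOCC5)cc4[nH]3)C[C@H]2C)n1`, gives 545 ng.h/mL in this assay. Compound 2 thus stands at the lower of the two numbers, but the gap between compound 1 and compound 2 is within the usual scatter, so the two exposures cannot be told apart.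

Compound 3, `Cc1nc(C)n(CC(=O)N2CCN(c3sc(C(F)(F)F)nc3-c3nc4ccc(C5CCN(C)CC5)cc4[nH]3)C[C@H]2C)n1`, has not yet been measured in this assay. It differs from compound 2 in one place: 1-methylpiperidin-4-yl in place of oxan-4-yl on an aromatic carbon. Among the measured compounds shown here, no measured pair in this set carries a comparable change, so there is no step to lean on. Compound 3 is expected to show a step of a 1.6-fold lower number from compound 2 to compound 3 (0.19 log units; within the scatter) in this assay, a downward move that may or may not exceed the scatter. The estimate for compound 3 in this assay is 350 ng.h/mL, with a range from 120 ng.h/mL to 1000 ng.h/mL; a number close to that of compound 2 would not be surprising.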

Compound 3, area under the concentration-time curve: 54.6 ng.h/mL
Compound 3: middle estimate off by 6.4-fold (0.81 log units), on the high side; the whole stated range lies above it.
By their numbers in this assay, from the lowest: compound 3; then compounds 2 and 1 (each within the scatter of the next).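

Among the compounds shown here, replacing oxan-4-yl with 1-methylpiperidin-4-yl on this aromatic carbon gives a 10-fold lower number from compound 2 to compound 3 (1.00 log units; beyond the scatter) in this assay, and this is the first step in the set that can be tied to a single place in the structure. It shows that exposure after oral dosing is sensitive to the group at this position, meta to a fused ring and para to a fused ring, even though the two groups are alike in the counts computed for them: each is a six-membered non-aromatic ring with one hetero atom, no hydrogen-bond donors and one hydrogen-bond acceptor. Nothing in the data shown gives a measured property that would explain the size of this step.

As far as these compounds go, what a piperidin-4-yl without the methyl group, a 1-acetylpiperidin-4-yl or a carboxylic acid at this carbon would give remains open, so the step cannot yet be assigned to the ring nitrogen or to its methyl group. Also open, from the compounds shown here alone, is whether the same exchange would give a step of similar size with the other parts of the molecule changed, and whether the lower exposure reflects uptake or clearance.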